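The source may report more compounds than this note shows. Statements on the series, on what has been measured and on what is new or still open speak of the compounds shown alone.

Three compounds, all carrying the same core, have been tested in a functional assay on the whole organism with Mus musculus as the target, in the hot plate test; on this read-out higher numbers stand for an effect only at larger amounts of compound and lower numbers for an effect already at smaller amounts. Compound 1, `Clc1ccc2[nH]cc(SC3CCNCC3)c2c1`, gives 1.2 mg/kg. Compound 2, `CC(=O)N1CCC(Sc2c[nH]c3ccc(Br)cc23)CC1`, gives 2.8 mg/kg. Compound 3, `Cc1[nH]c2ccc(Cl)cc2c1SC1CCNCC1`, gives 9.9 mg/kg and so stands highest of the three numbers, with compound 2 nearest and compound 1 furthest. For the measured compounds named here, the only single-point change among the measured compounds is the one from compound 1 to compound 3, an 8.3-fold higher number from compound 1 to compound 3 (0.92 log units; beyond the scatter).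

Compound 4, `Cc1[nH]c2ccc(F)cc2c1SC1CCNCC1`, differs from compound 3 by fluoro in place of chloro on an aromatic carbon. Going by the values given here, no measured step touches the halogen on this ring: compound 2 carries a bromine there, but it also differs from compound 3 at two other places, so its value alone shows nothing about the halogen swap. Without a comparable step, the expectation for compound 4 in this assay is a small shift, within the usual scatter, estimated as a 1.2-fold higher number from compound 3 to compound 4 (0.08 log units; within the scatter). Compound 4 is therefore expected to give about 12 mg/kg, with a likely range from 4 mg/kg to 35 mg/kg.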

Compound 4, dose for half-maximal effect: 12.7 mg/kg
The estimate for compound 4 lay 1.1-fold (0.02 log units) below the measured number, within the range that was stated.
By their numbers in this assay, from the lowest: compound 1; then compound 2; then compounds 3 and 4 (each within the scatter of the next).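

For the compounds shown here, this is the first direct reading of the halogen on the aromatic ring: in this assay, fluoro in place of chloro gives a 1.3-fold higher number from compound 3 to compound 4 (0.11 log units; within the scatter). With the methyl group in place, then, this one exchange of halogen makes no clear difference to the dose needed, unlike the methyl change, which gave an 8.3-fold higher number from compound 1 to compound 3 (0.92 log units; beyond the scatter). No measurement is available that could explain why the exchange of chloro for fluoro leaves the result within the scatter.

On these data alone, it remains open whether a group of a different kind at this position, such as methoxy or a nitrile, would also leave the dose unchanged. As far as these compounds go, it is also open whether the same exchange of chloro for fluoro would behave alike on the core of compound 1, which has no methyl group.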